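A few compounds are considered here, and "the series" means these few. Any claim that something is new, unique, unknown or untested is made for them only; others in the source may bear on it.

Measured so far in an assay on HT-29 cells for inhibition of Serine-protein kinase ATM (Homo sapiens), read by fluorescence, with a stated time of 1 h; a lower number here means a stronger inhibitor, a higher number a weaker inhibitor:
- compound 1 `CCC(CC)CNc1c(C(N)=O)cnc2ccc(C#N)cc12`: 820 nM
- compound 2 `CCC(CC)CNc1c(C(N)=O)cnc2ccc(-c3ccc(COC)cc3)cc12`: 373 nM

Within the data shown here, on these two numbers compound 2 stands lowest; the only comparison is to compound 1, and that step, a 2.2-fold lower number from compound 1 to compound 2 (0.34 log units; beyond the scatter), is beyond the scatter but modest in size. It shows that an aryl group on this aromatic carbon in place of cyano is tolerated and helps somewhat.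

Compound 3 `CCC(CC)CNc1c(C(N)=O)cnc2ccc(-c3ccnnc3)cc12` carries the change (pyridazin-4-yl in place of 4-(methoxymethyl)phenyl on an aromatic carbon). Among the measured compounds shown here, no measured step in this assay touches an aryl-for-aryl exchange at this position; the single step from compound 1 to compound 2 only shows that the site accepts a six-membered aromatic ring. With a second aromatic ring kept in place, the expectation for compound 3 is a number close to that of compound 2, the estimated step being a 1.1-fold higher number from compound 2 to compound 3 (0.05 log units; within the scatter), within the scatter. Compound 3 is therefore estimated at 420 nM, with a range of 150 nM to 1200 nM.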

Compound 3, half-maximal inhibitory concentration: 908 nM
Estimate against measurement, compound 3: 2.2-fold (0.33 log units) below, within the range that was stated.
By their numbers in this assay, from the lowest: compound 2; then compounds 1 and 3 (each within the scatter of the next).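

In this assay, exchanging one aromatic ring for another at this position is not neutral: a 2.4-fold higher number from compound 2 to compound 3 (0.39 log units; beyond the scatter), so the presence of a six-membered aromatic ring alone does not account for the lower number of compound 2. Pyridazin-4-yl and cyano cannot be separated on these data, with a 1.1-fold higher number from compound 1 to compound 3 (0.04 log units; within the scatter); across these three compounds, only 4-(methoxymethyl)phenyl gives a number beyond the scatter of the others. No available evidence bears on the reason for the difference between the two rings.

As far as these compounds go, it remains open whether the lower number of compound 2 follows from the ring of carbon only or from its methoxymethyl group, a question that plain phenyl would help to settle. Also open, from the compounds shown here alone, is how an amine or a carboxylic acid in place of the methoxymethyl group would read.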